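The source may hold more compounds than are shown below. What is called first, only, known or untested is meant among the compounds shown, and "the series" means these compounds.

Compound 3 `Cc1cc(C)c(S(C)(=O)=O)cc1C(=O)N=C(N)N` is the reference point of this account. In a functional assay for inhibition of sodium/hydrogen exchanger (Oryctolagus cuniculus) (a lower number here means a stronger inhibitor, a higher number a weaker inhibitor), compound 3 gives 11 nM, the lowest of the three numbers recorded so far. The nearest of the others is compound 1 `Cc1c(C(=O)N=C(N)N)cc(S(C)(=O)=O)c(Cl)c1C`, which in this assay gives 58 nM; the gap between the two lies beyond the scatter of repeated measurements. The furthest is compound 2 `CCN(CC)Cc1cc(Br)c(S(C)(=O)=O)cc1C(=O)N=C(N)N`, which in this assay gives 9500 nM, again well beyond the scatter. Compound 3 thus stands as the strongest inhibitor of the three that have been measured.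

Compound 4 `CCC(C)c1cc(C)c(C(=O)N=C(N)N)cc1S(C)(=O)=O` has not yet been measured. Relative to compound 3, its structure differs in one place: sec-butyl in place of methyl on an aromatic carbon. Among the compounds with values here, no pair of measured compounds shows an exchange of this kind, so the size and direction of the step rest on expectation alone. The sec-butyl chain simply takes the place of the methyl group, and every other substituent remains as in compound 3. The expectation is a modest loss of potency, a step of a 2.7-fold higher number from compound 3 to compound 4 (0.44 log units; beyond the scatter) that may or may not exceed the scatter. The estimate for compound 4 in this assay is 30 nM, with a range from 8 nM to 120 nM.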

Compound 4, half-maximal inhibitory concentration: 8 nM
Compound 4: the middle estimate sits 3.8-fold (0.57 log units) above what was measured; low and high end bracket the measured number.
By their numbers in this assay, from the lowest: compounds 4 and 3 (each within the scatter of the next); then compound 1; then compound 2.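

In this assay, sec-butyl in place of methyl on this aromatic carbon gives a 1.4-fold lower number from compound 3 to compound 4 (0.14 log units; within the scatter), so the two compounds cannot be told apart in this read-out. The earlier compounds shown here could not show this, since no two of them differ in one place; this pair shows that at the position ortho to a methylsulfonyl group and para to a group of 6 heavy atoms, a branched chain of 4 heavy atoms can replace a methyl group of 1 heavy atom without a step beyond the scatter. Nothing in the material at hand accounts for this result.

The compounds shown leave open whether a longer chain, an amine or a carboxylic acid in this place would keep the number close to that of compound 3 at 11 nM. They also leave open whether sec-butyl would give a step of similar size if the methyl group meta to this position were exchanged for another group, since that neighbouring substituent stays the same in this pair.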